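A Pyrazole in Place of Chlorophenyl: Expected Receptor Binding

The source may hold more compounds than are shown below. What is called first, only, known or untested is meant among the compounds shown, and "the series" means these compounds.

Compound 1 `CC(C)(C)Cc1c(-c2ccc(Cl)cc2)sc(N)c1C(=O)c1ccc(Cl)cc1` was tested in an assay on CHO cells for displacement of a labelled ligand from adenosine receptor A3 (Homo sapiens), read by scintillation counting, tested at 10 uM (a higher number here means more inhibition at the concentration tested (going by the name of the read-out), a lower number less inhibition), where compound 1 gives 1%. Two companions share its core and differ from it only on one aromatic ring: compound 2 `COCCOc1ccc(-c2sc(N)c(C(=O)c3ccc(Cl)cc3)c2CC(C)(C)C)cc1` gives 1%, and compound 3 `CC(C)(C)Cc1c(-c2ccc(OC(F)(F)F)cc2)sc(N)c1C(=O)c1ccc(Cl)cc1` gives 1%. The steps among them are flat: no change at the digits printed from compound 1 to compound 2 (within the scatter), no change at the digits printed from compound 1 to compound 3 (within the scatter), and no change at the digits printed from compound 2 to compound 3 (within the scatter). Compound 1 therefore stands level with compounds 2 and 3, and all three show essentially no displacement of the labelled ligand at the concentration tested.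

Compound 4 `CC(C)(C)Cc1c(-c2cn[nH]c2)sc(N)c1C(=O)c1ccc(Cl)cc1` has not been measured. It differs from compound 1 in one place: 1H-pyrazol-4-yl in place of 4-chlorophenyl on an aromatic carbon. Among the compounds with values here, none of the measured steps touches this kind of change; each of them exchanges a group on the 4-chlorophenyl ring, and each left the read-out unchanged. That gives no basis to expect binding to appear, so compound 4 is expected to stay near the floor, with an expected step of a number 2 percentage points higher from compound 1 to compound 4 (within the scatter). The estimate for compound 4 is 3%, with an expected range from -10% to 20%.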

Compound 4, a percentage reported as inhibition, at one concentration (the size of the read-out at that concentration, not a potency): 1%
The estimate for compound 4 lay 2 percentage points above the measured number, within the range that was stated.
By their numbers in this assay, from the lowest: compounds 1, 2, 3 and 4 (each within the scatter of the next).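

The earlier steps shown here only exchanged a group on the 4-chlorophenyl ring, whereas here that whole ring gives way to 1H-pyrazol-4-yl on the aromatic carbon next to the ring sulfur, and in this assay the result is no change at the digits printed from compound 1 to compound 4 (within the scatter). So at this position, neither the swap of a six-membered carbon ring for a five-membered ring with 2 hetero atoms nor the arrival of a hydrogen-bond donor and acceptor lifts the reading in this series. Nothing available explains why the reading stays flat.

On these data alone, all four compounds keep the neopentyl group, the amino group and the (4-chlorophenyl)carbonyl group, so what changes at those places would do remains open. Also open, as far as these compounds go, is whether a carboxylic acid or an aminomethyl group at the pyrazole's position would leave the reading equally flat.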